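Trading a Trifluoromethyl for Dichloro on the Urea Aryl

A few compounds are considered here, and "the series" means these few. Any claim that something is new, unique, unknown or untested is made for them only; others in the source may bear on it.

The series is built on one shared core bearing a pyridyl group and a chlorinated phenol or its methoxy counterpart. Compound 1 `O=C(Nc1cccc(-n2cc(-c3ccncc3)c(-c3ccc(Cl)c(O)c3)n2)c1)Nc1cccc(C(F)(F)F)c1` is measured in a functional assay on UO-31 cells (Homo sapiens) for inhibition, read by sulforhodamine B assay, with a stated time of 48 h (on this read-out lower numbers stand for stronger inhibition of growth and higher numbers for weaker inhibition of growth), and gives 1860 nM; this is the highest of the three numbers shown. Compound 2 `COc1cc(-c2nn(-c3cccc(NC(=O)Nc4cc(C(F)(F)F)cc(C(F)(F)F)c4)c3)cc2-c2ccncc2)ccc1Cl` gives 600 nM, a gap from compound 1 that lies beyond the scatter, while compound 3 `COc1cc(-c2nn(-c3cccc(NC(=O)c4cccc(C(F)(F)F)c4)c3)cc2-c2ccncc2)ccc1Cl` gives 968 nM, which falls within the scatter of compound 1.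

Compound 4 `O=C(Nc1cccc(-n2cc(-c3ccncc3)c(-c3ccc(Cl)c(O)c3)n2)c1)Nc1ccc(Cl)c(Cl)c1` differs from compound 1 by one change: 3,4-dichlorophenyl in place of 3-(trifluoromethyl)phenyl on an amide-type nitrogen. For the measured compounds named here, no measured pair isolates this change, so the step of a 1.2-fold lower number from compound 1 to compound 4 (0.09 log units; within the scatter) is expected to be small, in either direction, and not clearly beyond the scatter. Compound 4 is therefore estimated at 1500 nM, within a range of 500 nM to 4500 nM.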

Compound 4, concentration for 50% growth inhibition: 1250 nM
The estimate for compound 4 lay 1.2-fold (0.08 log units) above the measured number, within the range that was stated.
By their numbers in this assay, from the lowest: compounds 2, 3, 4 and 1 (each within the scatter of the next, the first and the last beyond it).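

In this assay, for the compounds shown here, 3,4-dichlorophenyl in place of 3-(trifluoromethyl)phenyl on an amide-type nitrogen gives a 1.5-fold lower number from compound 1 to compound 4 (0.17 log units; within the scatter) and is the first step here that isolates a single change. At this position, on the phenol core, the two aryl groups are therefore not told apart by this read-out. Nothing at hand accounts for this result.

As far as these compounds go, whether a carboxylic acid or a dimethylamino group on this aryl ring would shift the number beyond the scatter stays open. So does whether the same exchange gives a similar step on the methoxy counterpart of the core.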